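The source may report more compounds than this note shows. Statements on the series, on what has been measured and on what is new or still open speak of the compounds shown alone.

Measured compounds:
Compound 1 `CCn1c(/C=C2\SC(=O)N(CC(=O)N3CCCCC3)C2=O)nc2ccccc21` — in a functional assay on A549 cells (Homo sapiens) for inhibition, read by MTT assay, with a stated time of 48 h (a lower number here means a stronger inhibitor, a higher number a weaker inhibitor), compound 1 gives only a limit, > 50000 nM.
Compound 2 `Cn1c(/C=C2\SC(=O)N(CC(=O)N3CCCCC3)C2=O)nc2ccccc21` — in this assay compound 2 gives only a limit, > 50000 nM.
Compound 3 `CCn1c(/C=C2\SC(=O)N(CC(=O)N3CCc4cc(OC)c(OC)cc4C3)C2=O)nc2ccccc21` — in this assay compound 3 gives 26200 nM.

From compound 2 to compound 1 the change is methyl in place of hydrogen on a saturated chain carbon bound to an aromatic nitrogen, and the step that the two limits leave unreadable from compound 2 to compound 1 cannot be sized because both values sit at the limit of > 50000 nM in this assay, at which 2 of the 3 values shown sit. Compound 4 `COc1cc2c(cc1OC)CN(C(=O)CN1C(=O)S/C(=C\c3nc4ccccc4n3C(C)C)C1=O)CC2` differs from compound 3 by methyl in place of hydrogen on a saturated chain carbon bound to an aromatic nitrogen and a saturated chain carbon. This is the same kind of change, though the place differs: here the carbon is bound to an aromatic nitrogen and a saturated chain carbon, there only to an aromatic nitrogen. The difference between the two cores is not broken down here. Since the earlier step is unreadable, the expectation rests on compound 3 at 26200 nM and on the small size of the added methyl, so the step of a 1.1-fold higher number from compound 3 to compound 4 (0.06 log units; within the scatter) is expected to be small. Compound 4 is therefore estimated at 30000 nM, expected between 10000 nM and 90000 nM.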

Compound 4, half-maximal inhibitory concentration: 20600 nM
Beside the measured number, compound 4's estimate is 1.5-fold (0.16 log units) above it; measured number inside the range.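

In this assay, the change from ethyl to isopropyl gives a 1.3-fold lower number from compound 3 to compound 4 (0.10 log units; within the scatter), so the two compounds cannot be told apart here. The related methyl addition from compound 2 to compound 1 sits on a different carbon and on a different core, and it cannot be read, because both of its values are limits: the limit of > 50000 nM in this assay, at which 2 of the 4 values shown sit. This leaves one readable step, which shows that the change made no measurable difference on one core but not whether the same would hold on another.

The compounds shown leave open what a longer chain, such as butyl, would do in place of the ethyl of compound 3. They also leave open the effect of a carboxylic acid or an amine at that place.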